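Swapping an Acyl Group for a Sulfamoyl Group

This account rests on a few compounds, and the source may have more. Where it says the series, first, only, none or still open, it means among the compounds named here.

In an ADME assay on L02 cells (Homo sapiens) for cytotoxicity, read by MTT assay, with a stated time of 48 h (a higher number here means a weaker inhibitor, a lower number a stronger inhibitor), compound 1 `O=C1O[C@@H](CN2CCC(O)CC2)CN1c1ccc(-n2cc(-c3ccccn3)cn2)c(F)c1` reaches only a limit of the assay, > 400 ug/mL. For the measured compounds named here, compound 2 `CCC(=O)NC[C@H]1CN(c2ccc(-n3cc(-c4ccccn4)cn3)c(F)c2)C(=O)O1` gives 204 ug/mL, the only true number so far. Compound 3 `CN(C)S(=O)(=O)NC[C@H]1CN(c2ccc(-n3cc(-c4ccccn4)cn3)c(F)c2)C(=O)O1` carries dimethylsulfamoyl in place of propanoyl on an amine nitrogen. Going by the values given here, the only measured step, an at least 1.9-fold lower number from compound 1 to compound 2 (0.29 log units; that floor lies within the scatter), replaces a different group, so it offers no direct guide to this change. Any shift is therefore expected to stay within the usual scatter, and the expected step is a 1.1-fold higher number from compound 2 to compound 3 (0.03 log units; within the scatter). Compound 3 is estimated at 220 ug/mL, with an expected range of 110 ug/mL to 400 ug/mL.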

Compound 3, half-maximal inhibitory concentration: 158 ug/mL
The estimate for compound 3 lay 1.4-fold (0.14 log units) above the measured number; the range from low to high includes it.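

Putting dimethylsulfamoyl in place of propanoyl on the amine nitrogen gives a 1.3-fold lower number from compound 2 to compound 3 (0.11 log units; within the scatter), so in this assay this swap leaves the reading essentially unchanged. For the compounds shown here, the wider change, (dimethylsulfamoyl)amino in place of 4-hydroxypiperidin-1-yl, gives an at least 2.5-fold lower number from compound 1 to compound 3 (0.40 log units; beyond the scatter), the only step here that clears the scatter. That step is only a floor, as it starts from the limit reached by compound 1: the limit of > 400 ug/mL in this assay, at which 1 of the 3 values shown sits.

The compounds shown leave open whether a free amine or a longer acyl chain on this nitrogen would read any differently.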